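This account rests on a few compounds, and the source may have more. Where it says the series, first, only, none or still open, it means among the compounds named here.

Measured compounds:
- Compound 1, `COc1cc2c(cc1OC)C(CC(=O)Nc1ccc(Cl)cc1)CC2`: 60.9%
- Compound 2, `COc1cc2c(cc1OC)C(CC(=O)Nc1ccc(C)cc1)CC2`: 34.8%

Within the data shown here, in a functional assay on the whole organism (strain Wistar) for inhibition, with Rattus norvegicus as the target, read by paw edema, with a stated time of 3 h, at a dose of 100 mg/kg (on this read-out higher numbers stand for more inhibition at the one dose given (going by the name of the read-out) and lower numbers for less inhibition), compound 1 gives 60.9%, and compound 2 gives 34.8%, the lower of the two numbers; the one measured step, a number 26.1 percentage points lower from compound 1 to compound 2 (beyond the scatter), lies beyond the scatter. Compound 3, `COc1cc2c(cc1OC)C(CC(=O)Nc1ccncc1)CC2`, has not yet been measured. It differs from compound 2 in one place: pyridin-4-yl in place of 4-methylphenyl on an amide-type nitrogen. The entering group brings one six-membered aromatic ring with 1 hetero atom and 1 hydrogen-bond acceptor where the leaving group had a ring of carbon only. Among the measured compounds shown here, no measured step covers this kind of change; the step from compound 1 to compound 2 concerns a different exchange on the same ring, so it only shows that changes at this position can move the read-out by a modest amount. For compound 3 in this assay a step of about a number 5.2 percentage points higher from compound 2 to compound 3 (within the scatter) is expected, which is not beyond the scatter. Compound 3 is therefore estimated at 40%, between 15% and 65%.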

Compound 3, a percentage reported as inhibition, in the whole organism at one dose (the size of the read-out at that dose, not a potency): 42%
Compound 3: the middle estimate sits 2 percentage points below what was measured, within the range that was stated.
By their numbers in this assay, from the lowest: compounds 2 and 3 (each within the scatter of the next); then compound 1.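

In this assay pyridin-4-yl in place of 4-methylphenyl on the amide-type nitrogen gives a number 7.2 percentage points higher from compound 2 to compound 3 (within the scatter) and so leaves the read-out within the scatter, which means these two groups cannot be told apart here. Pyridin-4-yl in place of 4-chlorophenyl gives a number 18.9 percentage points lower from compound 1 to compound 3 (beyond the scatter) and thus shows that a ring with a hydrogen-bond acceptor did not, in compound 3, reach the level of the 4-chlorophenyl group in compound 1. No measurement shown offers an explanation for these results.

Going by these compounds, whether a 4-bromophenyl or 4-methoxyphenyl group on the same nitrogen would read like compound 1 or like compound 2 stays open, as does the reading of a pyridin-3-yl group. On these data alone, all three compounds also share the same core and amide link, so the effect of changes there, such as an amine in place of the amide, remains unknown.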